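The source may hold more compounds than are shown below. What is called first, only, known or untested is meant among the compounds shown, and "the series" means these compounds.

Compound 1, `COC(/C=C/c1ccccc1)=C1\C(=O)C=C(C)C1=O`, was tested in an ADME assay on Vero cells (Chlorocebus sabaeus) for cytotoxicity, read by neutral red uptake (a higher number here means a weaker inhibitor, a lower number a stronger inhibitor), where compound 1 gives 4.9 ug/mL. Among the three measured compounds this number is the second highest. The nearest neighbour is compound 3, `CCOC(/C=C/c1ccccc1)=C1\C(=O)C=C(C)C1=O`, which gives 4.8 ug/mL; the furthest is compound 2, `COC(/C=C/c1ccc(Cl)cc1)=C1\C(=O)C=C(C)C1=O`, which gives 5.5 ug/mL. Both gaps lie within the scatter of repeated measurements.

Compound 4, `COC(/C=C/c1cccs1)=C1\C(=O)C=C(C)C1=O`, has not yet been measured. It differs from compound 1 in one place: thiophen-2-yl in place of phenyl on a double-bonded chain carbon bound to a double-bonded chain carbon.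

Two measured steps start from compound 1. Putting chloro in place of hydrogen on an aromatic carbon gave a 1.1-fold higher number from compound 1 to compound 2 (0.05 log units; within the scatter). Putting methyl in place of hydrogen on a saturated chain carbon bound to an oxygen on an unsaturated carbon gave a 1.0-fold lower number from compound 1 to compound 3 (0.01 log units; within the scatter). Going by the values given here, neither step exchanges the aromatic ring itself, so neither bears directly on the change to compound 4; they show only that the numbers so far move little. With nothing pointing elsewhere, the expected step is a 1.0-fold higher number from compound 1 to compound 4 (0.01 log units; within the scatter), that is, none beyond the scatter. Compound 4 is therefore estimated at 5 ug/mL, with a likely range from 2.5 ug/mL to 10 ug/mL.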

Compound 4, half-maximal inhibitory concentration: 3 ug/mL
Beside the measured number, compound 4's estimate is 1.7-fold (0.22 log units) above it, and the stated range covers the measured number.
By their numbers in this assay, from the lowest: compounds 4, 3, 1 and 2 (each within the scatter of the next).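

Compound 4 is the first of these compounds in which the aromatic ring itself is exchanged, rather than a hydrogen being replaced elsewhere, and swapping phenyl for thiophen-2-yl on a double-bonded chain carbon bound to a double-bonded chain carbon gave a 1.6-fold lower number from compound 1 to compound 4 (0.21 log units; within the scatter) in this assay. So, in this one pair, going from a six-membered carbon ring to a five-membered ring with one hetero atom cannot be told apart from the spread of repeated measurements. Nothing available here bears on why the step is this small.

From the compounds shown here alone, whether furan-2-yl or pyridin-2-yl at this place, or an amine or a carboxylic acid carried on the ring, would move the number beyond the scatter stays open. Also open, going by these compounds, is whether thiophen-2-yl behaves alike with the ethyl ether of compound 3 or with a longer chain on that oxygen.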